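The source may report more compounds than this note shows. Statements on the series, on what has been measured and on what is new or still open speak of the compounds shown alone.

Compound 1 `C=C1C(=O)OC[C@H]1CCOC(=O)Nc1ccc(C(C)C)cc1` gives the lowest of the three numbers measured in a functional assay on RAW264.7 cells (Mus musculus) for inhibition, with a stated time of 30 min (a lower number here means a stronger inhibitor, a higher number a weaker inhibitor), with 340 nM. Compound 2 `C=C1C(=O)OC[C@H]1CCOC(=O)Nc1ccccc1` stands closest, with 390 nM, and the step of a 1.1-fold higher number from compound 1 to compound 2 (0.06 log units; within the scatter) comes from replacing the isopropyl with a hydrogen. Compound 3 `C=C1C(=O)OC[C@@H]1CCOC(=O)Nc1ccc(I)cc1` lies furthest away, with 790 nM; it carries iodine and the opposite configuration at the ring carbon, so its gap to compound 1 cannot be attributed to either change alone.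

Compound 4 `C=C1C(=O)OC[C@@H]1CCOC(=O)Nc1ccc(C(C)C)cc1` is the mirror-image partner of compound 1: the two compounds have the same atoms and bonds and differ only in configuration as drawn: 1 of 1 stereo elements differ; a stereocentre at a saturated ring carbon is drawn S in compound 1 and R in compound 4. Among the measured compounds shown here, no measured pair isolates this kind of change, so no step directly bears on it. Compound 4 is therefore expected to give a number near compound 1, with a wide range, estimated at 600 nM between 250 nM and 2000 nM, a step of a 1.8-fold higher number from compound 1 to compound 4 (0.25 log units; within the scatter).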

Compound 4, half-maximal inhibitory concentration: 1580 nM
Estimate against measurement, compound 4: 2.6-fold (0.42 log units) below; the range from low to high includes it.
By their numbers in this assay, from the lowest: compounds 1 and 2 (each within the scatter of the next); then compounds 3 and 4 (each within the scatter of the next).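

The step of a 4.6-fold higher number from compound 1 to compound 4 (0.67 log units; beyond the scatter) gives the first direct measure of this change at the ring carbon, and it can be assigned to configuration alone because of one fact: the fact that compounds 1 and 4 differ only in the configuration as drawn. Among compounds drawn R at that carbon, the step of a 2.0-fold higher number from compound 3 to compound 4 (0.30 log units; within the scatter) stays within the scatter, so swapping iodo for isopropyl does not separate these two compounds.

Only the isopropyl pair compares the two configurations. Going by these compounds, whether the gap holds with an amine or a carboxylic acid on the aromatic carbon stays open.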